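The compounds below may be only part of what the source reports. "The series", "measured", "known", "first", "only" and "open" are said of these compounds alone.

Measured in a functional assay on MCF7 cells (Homo sapiens) for cytotoxicity, read by MTT assay, with a stated time of 72 h; a lower number here means a stronger inhibitor, a higher number a weaker inhibitor:
- Compound 1 `COc1ncc(-c2ccc3nc(NC(=O)N(C)C)nn3c2)cc1NS(=O)(=O)c1ccc(F)cc1` gives 1560 nM
- Compound 2 `COc1ncc(-c2ccc3nc(NC(=O)NC4CC4)nn3c2)cc1NS(=O)(=O)c1ccc(F)cc1` gives 300 nM
- Compound 3 `COc1ncc(-c2ccc3nc(NC(=O)NCCN4CCCCC4)nn3c2)cc1NS(=O)(=O)c1ccc(F)cc1` gives 200 nM

Compound 1 stands highest of the three in this assay. Compound 4 `COc1ncc(-c2ccc3nc(NC(=O)NCCN4CCN(C)CC4)nn3c2)cc1NS(=O)(=O)c1ccc(F)cc1` has not yet been measured. It differs from compound 1 thus: (2-(4-methylpiperazin-1-yl)ethyl)amino in place of dimethylamino on a carbonyl carbon. Two measured replacements of the same dimethylamino group bear on this change: a 5.2-fold lower number from compound 1 to compound 2 (0.72 log units; beyond the scatter) and a 7.8-fold lower number from compound 1 to compound 3 (0.89 log units; beyond the scatter). The second brings in the more similar group, (2-(piperidin-1-yl)ethyl)amino, and the two products differ only within the scatter: a 1.5-fold lower number from compound 2 to compound 3 (0.18 log units; within the scatter). A modest step to a lower number is therefore expected in this assay. The estimated step is a 6.8-fold lower number from compound 1 to compound 4 (0.83 log units; beyond the scatter). The expected value for compound 4 is 230 nM, with an estimated range of 90 nM to 600 nM.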

Compound 4, half-maximal inhibitory concentration: 500 nM
Beside the measured number, compound 4's estimate is 2.2-fold (0.34 log units) below it, and the stated range covers the measured number.
By their numbers in this assay, from the lowest: compounds 3, 2 and 4 (each within the scatter of the next, the first and the last beyond it); then compound 1.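

In this assay, (2-(4-methylpiperazin-1-yl)ethyl)amino in place of dimethylamino on the carbonyl carbon again lowers the number, with a 3.1-fold lower number from compound 1 to compound 4 (0.49 log units; beyond the scatter). The new finding is that the ring at the end of the chain counts: 4-methylpiperazin-1-yl in place of piperidin-1-yl gives a 2.5-fold higher number from compound 3 to compound 4 (0.40 log units; beyond the scatter), while 2-(4-methylpiperazin-1-yl)ethyl in place of cyclopropyl gives only a 1.7-fold higher number from compound 2 to compound 4 (0.22 log units; within the scatter). Nothing available explains the difference between the two rings.

The compounds shown leave open how a morpholine ring on the same ethyl chain would stand in this assay, and whether a longer chain carrying the piperidine ring would keep the number of the ethyl chain.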